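The compounds below may be only part of what the source reports. "The series", "measured", "known", "first", "only" and "open" are said of these compounds alone.

Series notes. Three compounds are measured in a functional assay on HUVEC cells (Homo sapiens) for inhibition, with a stated time of 4 days; a lower number here means a stronger inhibitor, a higher number a weaker inhibitor. Compound 1, `COc1ccc(C(N)=O)cc1/C=C/c1ccc(Cl)cc1`, gives 87 nM. Compound 2, `COc1ccc(C(N)=O)cc1/C=C/c1ccc(C)cc1`, gives 1600 nM. Compound 3, `COc1ccc(C(N)=O)cc1/C=C/c1cccc(C)c1`, gives 3900 nM.

Compound 2 and compound 1 differ in one place: chloro in place of methyl on an aromatic carbon. That change gives an 18-fold lower number from compound 2 to compound 1 (1.26 log units; beyond the scatter). Compound 3 has the same atoms as compound 2, joined differently; the difference between the two cores is not broken down here. Compound 3 shows the higher number of the two.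

Compound 4, `COc1ccc(C(N)=O)cc1/C=C/c1cccc(Cl)c1`, is not yet measured. It relates to compound 3 by chloro in place of methyl on an aromatic carbon. This is the same kind of change as that from compound 2 to compound 1, but not the same: there the place was para to a large group, here it is meta to a large group.

The expectation for compound 4 rests on the step from compound 2 to compound 1, an 18-fold lower number from compound 2 to compound 1 (1.26 log units; beyond the scatter); a step of similar direction but possibly smaller size is expected, a 9.8-fold lower number from compound 3 to compound 4 (0.99 log units; beyond the scatter), since the place differs. Compound 4 is estimated at 400 nM in this assay, between 120 nM and 1500 nM.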

Compound 4, half-maximal inhibitory concentration: 24000 nM
Compound 4: middle estimate off by 60-fold (1.78 log units), on the low side, outside the stated range (above it).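

In this assay, chloro in place of methyl, meta to a large group, gives a 6.2-fold higher number from compound 3 to compound 4 (0.79 log units; beyond the scatter), so the change does not carry over in direction from the pair of compound 2 and compound 1: the same change on two cores in this assay, an 18-fold lower number (1.26 log units; beyond the scatter) from compound 2 to compound 1 and a 6.2-fold higher number (0.79 log units; beyond the scatter) from compound 3 to compound 4, 110-fold (2.05 log units) apart, beyond the scatter of two such steps

For this series, the result of swapping methyl for chloro on one core cannot be taken as a guide to the same swap on the other, and a step measured at one place should not be transferred to another. It does not show why the two steps part ways, nor whether the reversal is general, as each place is represented by a single pair and no property of either group has been measured here.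

Open, as far as these compounds go, is whether fluoro, trifluoromethyl or a nitrile at these two places would follow chloro or methyl. Also open, from the compounds shown here alone, is whether the contrast between the two places survives when the carboxamide of the shared core gives way to a carboxylic acid or an amine.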